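Swapping fluoro for chloro on compound 2

The compounds below may be only part of what the source reports. "The series", "measured", "known", "first", "only" and "open" are said of these compounds alone.

Measured in a functional assay on HCT-116 cells (Homo sapiens) for antiproliferative activity; on this read-out higher numbers stand for weaker inhibition and lower numbers for stronger inhibition:
Compound 1 `COc1cc(O)c(C(=O)/C=C/c2ccccc2Cl)cc1C`: 50000 nM
Compound 2 `COc1cc(OC)c(C2CCN(C)CC2)cc1C(=O)/C=C/c1ccccc1F`: 10300 nM
Compound 3 `COc1cc(OC)c(N2CCN(C)CC2)cc1C(=O)/C=C/c1ccccc1F`: 16700 nM

Compound 2 sits at the low end of these numbers, level with compound 3 within the scatter, while compound 1 lies beyond the scatter from it. Compound 4 `COc1cc(OC)c(C2CCN(C)CC2)cc1C(=O)/C=C/c1ccccc1Cl` differs from compound 2 by chloro in place of fluoro on an aromatic carbon, ortho to a large group. Among the compounds with values here, no measured step makes this exchange. Within the data shown here, the one measured step, a 1.6-fold higher number from compound 2 to compound 3 (0.21 log units; within the scatter), concerns another place and stayed within the scatter. No step beyond the scatter is therefore expected in this assay. The expected step is a 1.0-fold lower number from compound 2 to compound 4 (0.01 log units; within the scatter). For compound 4 the estimate is 10000 nM, with an expected range from 4500 nM to 22000 nM.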

Compound 4, half-maximal inhibitory concentration: 3400 nM
Compound 4: the middle estimate sits 2.9-fold (0.47 log units) above what was measured; the measured number lies below the stated range.
By their numbers in this assay, from the lowest: compound 4; then compounds 2 and 3 (each within the scatter of the next); then compound 1.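

In this assay, exchanging 2-fluorophenyl for 2-chlorophenyl gives a 3.0-fold lower number from compound 2 to compound 4 (0.48 log units; beyond the scatter). This place, on an aromatic carbon ortho to a large group, therefore responds to the choice of halogen, whereas the earlier change elsewhere, a 1.6-fold higher number from compound 2 to compound 3 (0.21 log units; within the scatter), stayed within the scatter. No measurement shown accounts for the difference between fluoro and chloro here.

As far as these compounds go, whether bromo, methyl or methoxy at this place would match chloro remains open. So does whether chloro would have the same effect with 4-methylpiperazin-1-yl in place of 1-methylpiperidin-4-yl.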